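A few compounds are considered here, and "the series" means these few. Any claim that something is new, unique, unknown or untested is made for them only; others in the source may bear on it.

Measured so far in an ADME assay on microsomes from liver (Homo sapiens) for metabolic stability, read by LC-MS, with a stated time of 10 min; on this read-out lower numbers stand for a less stable compound and higher numbers for a more stable compound:
compound 1 `CN(C[C@H]1Cc2c(cccc2N2CCNC(C)(C)C2)CN1)[C@H]1CCCc2cccnc21` gives 100%
compound 2 `FC1(F)CCC(CN(C[C@H]2Cc3c(cccc3N3CCNCC3)CN2)[C@H]2CCCc3cccnc32)CC1` gives 68.6%
compound 3 `CCN(C[C@H]1Cc2c(cccc2N2CCNCC2)CN1)[C@H]1CCCc2cccnc21` gives 79.1%

Compound 3 stands second highest of the three, below compound 1 and above compound 2, with both gaps beyond the scatter. Compound 4 `CCCN(C[C@H]1Cc2c(cccc2N2CCNCC2)CN1)[C@H]1CCCc2cccnc21` lengthens the ethyl of compound 3 to propyl (methyl in place of hydrogen on a saturated chain carbon, two bonds along the chain from an amine nitrogen), which is methyl in place of hydrogen on a saturated chain carbon, two bonds along the chain from an amine nitrogen. For the measured compounds named here, one measured step bears on this (a number 10.5 percentage points higher from compound 2 to compound 3 (beyond the scatter)), modest in size, with methyl in place of the far larger 4,4-difluorocyclohexyl. Read backwards, it suggests a lower number as the group grows, so in this assay a small fall is expected here (a number 4.1 percentage points lower from compound 3 to compound 4 (within the scatter)), probably within the scatter. For compound 4 the estimated value is 75% with an expected range from 62% to 88% on this read-out.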

Compound 4, percent of the compound remaining: 100%
For compound 4 the middle estimate is 25 percentage points below the measured one; measured number outside the range, above it.
By their numbers in this assay, from the lowest: compound 2; then compound 3; then compounds 1 and 4 (each within the scatter of the next).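

In this assay, going from ethyl to propyl gives a number 20.9 percentage points higher from compound 3 to compound 4 (beyond the scatter) and shows that this position does not simply lose stability as the group grows. Replacing the 4,4-difluorocyclohexyl group also gives a number 31.4 percentage points higher from compound 2 to compound 4 (beyond the scatter) and places propyl well clear of that larger group, while compound 3, with the shorter chain, goes against any size trend. Nothing at hand explains the rise.

On these data alone, a butyl or longer chain remains open, as does a branched isopropyl group. So does whether the methyl change holds with another amine on the core.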